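The source may report more compounds than this note shows. Statements on the series, on what has been measured and on what is new or still open speak of the compounds shown alone.

Compound 1 `C#CCOc1c(CC#C)c(O)nc2ccccc12`: 147000 nM
Compound 2 `CC(C)=CCOc1cc(O)nc2ccccc12`: 77400 nM
Compound 3 `CC(C)CCOc1cc(O)nc2ccccc12`: 115000 nM

In an ADME assay on CCRF-CEM cells (Homo sapiens) for cytotoxicity, read by MTT assay, with a stated time of 72 h (on this read-out lower numbers stand for higher toxicity in this test and higher numbers for lower toxicity in this test), compound 3 gives 115000 nM, which lies within the scatter of the values for compound 1 and compound 2. Compound 4 `C#CCOc1cc(O)nc2ccccc12` has ethynyl in place of isobutyl on a saturated chain carbon bound to an oxygen on an aromatic ring. Going by the values given here, the one measured step at this place, a 1.5-fold higher number from compound 2 to compound 3 (0.17 log units; within the scatter), stayed within the scatter, though it involved a different exchange. Compound 1, which also carries propargyl, gives 147000 nM. No change beyond the scatter is therefore expected in this assay, and the expected step is a 1.1-fold lower number from compound 3 to compound 4 (0.04 log units; within the scatter). For compound 4 the estimated value is 105000 nM, with an expected range of 55000 nM to 200000 nM.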

Compound 4, half-maximal cytotoxic concentration: 103000 nM
Compound 4: the middle estimate sits 1.0-fold (0.01 log units) above what was measured; low and high end bracket the measured number.
By their numbers in this assay, from the lowest: compounds 2, 4, 3 and 1 (each within the scatter of the next).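

In this assay, ethynyl in place of isobutyl at the saturated chain carbon stays within the scatter (a 1.1-fold lower number from compound 3 to compound 4 (0.05 log units; within the scatter)), as does ethynyl in place of 2-methylprop-1-en-1-yl (a 1.3-fold higher number from compound 2 to compound 4 (0.12 log units; within the scatter)), so these three chains on the oxygen are not told apart here. The aromatic carbon now has a step of its own: hydrogen in place of propargyl also stays within the scatter (a 1.4-fold lower number from compound 1 to compound 4 (0.15 log units; within the scatter)). No evidence on these results is at hand.

Going by these compounds, whether an amine, a carboxylic acid or a longer chain at the oxygen-bound carbon would move the number beyond the scatter stays open. So does the effect of any group other than propargyl on the aromatic carbon.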